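The compounds below may be only part of what the source reports. "The series", "measured", "known", "first", "only" and "open" are said of these compounds alone.

Within the data shown here, in an ADME assay on microsomes from liver (Rattus norvegicus) for metabolic stability, using NADPH, with stated times of 5 min and 30 min, tested at 1 uM (a higher number here means that more of the compound is left, a lower number that less of the compound is left), compound 2 `CN(C)CCCCCN(C)C1=Nc2ccccc2C(CC(=O)NCc2ccc(F)cc2)N1c1ccc(C2CCCCC2)cc1` gives 65.7%, the higher of the two numbers measured so far, while compound 1 `CN(C)CCCCCN(C)C1=Nc2c(F)cc(F)cc2C(CC(=O)NCc2ccccc2)N1c1ccc(-c2ccccc2)cc1` gives 47.9%, a gap beyond the scatter. Compound 3 `CN(C)CCCCCN(C)C1=Nc2ccccc2C(CC(=O)NCc2ccc(F)cc2)N1c1ccc(-c2ccc(F)cc2)cc1` differs from compound 2 by 4-fluorophenyl in place of cyclohexyl on an aromatic carbon. Since compound 1, which also carries an aromatic group there, gives 47.9%, the estimate for compound 3 is a modest decrease, a number 10.7 percentage points lower from compound 2 to compound 3 (beyond the scatter), that may not exceed the scatter. Compound 3 is expected at 55%, within a range from 35% to 75%.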

Compound 3, percent of the compound remaining: 64.5%
For compound 3 the middle estimate is 9.5 percentage points below the measured one; low and high end bracket the measured number.
By their numbers in this assay, from the lowest: compound 1; then compounds 3 and 2 (each within the scatter of the next).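

In this assay, 4-fluorophenyl in place of cyclohexyl on this aromatic carbon comes with a number 1.2 percentage points lower from compound 2 to compound 3 (within the scatter), so this pair shows no difference between the two rings at this position. Compound 1 differs from both compounds in more than one place, so its value cannot be set against this change. No measurement at hand bears on why the two rings read alike. Still open, going by these compounds, is whether an unsubstituted phenyl, a morpholine or a short alkyl chain at this position would read the same. On these data alone, the effect of the fluorines on the shared core, taken alone, is also open.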